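The source may report more compounds than this note shows. Statements on the series, on what has been measured and on what is new or still open speak of the compounds shown alone.

Compound 1, `Fc1ccccc1CSc1nnc(-c2cnccn2)o1`, is the reference point of this small set. In a functional assay on BGC-823 cells (Homo sapiens) for antiproliferative activity, read by MTT assay, with a stated time of 48 h (a lower number here means a stronger inhibitor, a higher number a weaker inhibitor), compound 1 gives 18200 nM. Compound 2, `Fc1cccc(F)c1CSc1nnc(-c2cnccn2)o1`, carries one more substituent on the same core. In this assay compound 2 reaches only a limit of the assay, > 50000 nM. The change from compound 1 to compound 2 is fluoro in place of hydrogen on an aromatic carbon, and it is accompanied by an at least 2.7-fold higher number from compound 1 to compound 2 (0.43 log units; beyond the scatter); the step can be stated only as a lower bound because of the limit of > 50000 nM in this assay, at which 1 of the 3 values shown sits.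

Compound 3, `Fc1ccccc1CSc1nnc(-c2cnccn2)s1`, keeps the same side chain on a different core; the difference between the two cores is not broken down here. In this assay compound 3 gives 18400 nM, a number within the usual scatter of the value of compound 1, so the two cannot be ranked against each other.

Compound 4, `Fc1cccc(F)c1CSc1nnc(-c2cnccn2)s1`, stands to compound 3 exactly as compound 2 stands to compound 1: the change is fluoro in place of hydrogen on an aromatic carbon, the same change at the same place. Since the two cores behaved alike in compound 1 and compound 3, the same change is expected to carry a similar step here. The measured step was an at least 2.7-fold higher number from compound 1 to compound 2 (0.43 log units; beyond the scatter). The expected step, on that basis, is a 3.3-fold higher number from compound 3 to compound 4 (0.51 log units; beyond the scatter). On that basis compound 4 is estimated at 60000 nM in this assay, most likely between 25000 nM and 150000 nM, with a real chance that the assay again reports only its limit. The measured value for compound 4 follows.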

Compound 4, half-maximal inhibitory concentration: 18600 nM
For compound 4 the middle estimate is 3.2-fold (0.51 log units) above the measured one; the measured number lies below the stated range.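

In this assay the entry of the fluoro group on the core of compound 3 leaves the number where it stood (a 1.0-fold higher number from compound 3 to compound 4 (0.00 log units; within the scatter)), so this change does not carry over from one core to the other in this pair of cores, and the step seen on the core of compound 1 cannot be taken as a guide to the step on the core of compound 3: the same change on two cores in this assay, an at least 2.7-fold higher number (0.43 log units; beyond the scatter) from compound 1 to compound 2 and a 1.0-fold higher number (0.00 log units; within the scatter) from compound 3 to compound 4, at least 2.7-fold (0.43 log units) apart, beyond the scatter of two such steps. Compound 2 gives > 50000 nM, which is a limit of the assay and not a number, so the earlier step is only a lower bound and the gap between the two steps has no known upper end: the limit of > 50000 nM in this assay, at which 1 of the 4 values shown sits. The two pairs show that the outcome of this change depends on the core here, but they do not show why the cores part, and one pair on each core says nothing about how the same change would behave on any further core.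

Still open, on these data alone, is whether a chloro, methyl or methoxy group entering at the same place would part the two cores as fluoro does. Equally open, as far as these compounds go, is what an amine or a carboxylic acid on the same six-membered aromatic ring would do on either core.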